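The compounds below may be only part of what the source reports. "The series", "measured", "known", "first", "only" and "open" are said of these compounds alone.

Measured so far in a functional assay for inhibition, with Homo sapiens as the target; a lower number here means a stronger inhibitor, a higher number a weaker inhibitor:
Compound 1, `NS(=O)(=O)c1ccc(Nc2nccc(-c3ccccn3)n2)cc1`, gives 4600 nM.
Compound 2, `NS(=O)(=O)c1cccc(Nc2nccc(-c3cccnc3)n2)c1`, gives 200 nM.
Compound 3, `CC(=O)Nc1ccc(Nc2nccc(-c3ccccn3)n2)cc1`, gives 1500 nM.

Compound 2 shows the lowest of the three numbers. Compound 3 differs from compound 1 by acetamido in place of sulfamoyl on an aromatic carbon, and that change brought a 3.1-fold lower number from compound 1 to compound 3 (0.49 log units; beyond the scatter). Compound 4, `CC(=O)Nc1cccc(Nc2nccc(-c3cccnc3)n2)c1`, is not yet measured; it differs from compound 2 by acetamido in place of sulfamoyl on an aromatic carbon. The cores of compound 1 and compound 2 are made of the same atoms joined differently, and the difference between the two cores is not broken down here. The change from compound 2 to compound 4 is the same kind of change as from compound 1 to compound 3, but the place differs: para to a large group in the earlier pair, meta to a large group here. Resting on a 3.1-fold lower number from compound 1 to compound 3 (0.49 log units; beyond the scatter), with allowance for the different place and core, a step of similar size is expected, a 2.2-fold lower number from compound 2 to compound 4 (0.35 log units; beyond the scatter). Compound 4 is therefore estimated at 90 nM, expected to fall between 35 nM and 300 nM.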

Compound 4, half-maximal inhibitory concentration: 3600 nM
Beside the measured number, compound 4's estimate is 40-fold (1.60 log units) below it; the whole stated range lies below it.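

In this assay, putting acetamido in place of sulfamoyl on the core of compound 2 gave an 18-fold higher number from compound 2 to compound 4 (1.26 log units; beyond the scatter). This change therefore does not carry over between these two cores, and even its direction reverses: the same change on two cores in this assay, a 3.1-fold lower number (0.49 log units; beyond the scatter) from compound 1 to compound 3 and an 18-fold higher number (1.26 log units; beyond the scatter) from compound 2 to compound 4, 55-fold (1.74 log units) apart, beyond the scatter of two such steps. Within the data shown here, with only two pairs, and with the cores differing as a whole, this shows that the effect depends on its surroundings but not which feature of the core is responsible.

As far as these compounds go, it remains open whether a carboxylic acid or an amine in the same place on the core of compound 2 would behave more like sulfamoyl or like acetamido. Also open, from the compounds shown here alone, is what the change does when the group's place shifts while the rest of the core stays fixed.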